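The source may hold more compounds than are shown below. What is called first, only, known or untested is meant among the compounds shown, and "the series" means these compounds.

Measured compounds:
- compound 1, `O=C1O[C@H]([C@@H](O)Cn2cc(-c3ccc(Br)cc3)nn2)C(OCc2ccccc2)=C1OCc1ccccc1`: 5070 nM
- compound 2, `O=C1O[C@H]([C@@H](O)Cn2cc(-c3cc(F)cc(F)c3)nn2)C(OCc2ccccc2)=C1OCc1ccccc1`: 11600 nM

In a functional assay on HepG2 cells (Homo sapiens) for antiproliferative activity, read by MTT assay, with a stated time of 72 h (a higher number here means a weaker inhibitor, a lower number a stronger inhibitor), compound 1 gives the lowest of the two numbers; compound 2 sits a 2.3-fold higher number from compound 1 to compound 2 (0.36 log units; beyond the scatter) away from it. Compound 3, `O=C1O[C@H]([C@@H](O)Cn2cc(CCO)nn2)C(OCc2ccccc2)=C1OCc1ccccc1`, is the next member of the series awaiting a number in this assay. Relative to compound 1 it carries 2-hydroxyethyl in place of 4-bromophenyl on an aromatic carbon. Among the measured compounds shown here, the only measured step, a 2.3-fold higher number from compound 1 to compound 2 (0.36 log units; beyond the scatter), exchanges one aryl group for another on that same triazole carbon and so bears on the change only loosely; no step exchanges an aryl group for a short chain. For the measured compounds named here, the one step available moved the number up on leaving the 4-bromophenyl group, so a further rise is expected here, plausibly a step of a 3.2-fold higher number from compound 1 to compound 3 (0.50 log units; beyond the scatter), with wide uncertainty. The estimate for compound 3 in this assay is 16000 nM, expected to fall between 5000 nM and 50000 nM.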

Compound 3, half-maximal inhibitory concentration: 68100 nM
For compound 3 the middle estimate is 4.3-fold (0.63 log units) below the measured one, outside the stated range (above it).
By their numbers in this assay, from the lowest: compound 1; then compound 2; then compound 3.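

In this assay the aromatic carbon of the five-membered aromatic ring with 3 nitrogen now shows an exchange of an aryl group for a short chain, and the number rises steeply: 2-hydroxyethyl in place of 4-bromophenyl gives a large step (a 13-fold higher number from compound 1 to compound 3 (1.13 log units; beyond the scatter)), and in place of 3,5-difluorophenyl a modest one (a 5.9-fold higher number from compound 2 to compound 3 (0.77 log units; beyond the scatter)). Both steps exceed the aryl-for-aryl step (a 2.3-fold higher number from compound 1 to compound 2 (0.36 log units; beyond the scatter)), so among these three compounds, losing the aromatic ring at this carbon costs more than changing the substituted phenyl group. Nothing available accounts for this rise.

The compounds shown leave open whether the rise follows the loss of the aromatic ring or the entry of the hydroxyl group. A plain butyl chain and a benzyl group at this carbon would help separate the two.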